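This account rests on a few compounds, and the source may have more. Where it says the series, first, only, none or still open, it means among the compounds named here.

Measured so far in a functional assay on HT cells (Homo sapiens) for antiproliferative activity, read by fluorescence, with a stated time of 72 h; on this read-out higher numbers stand for weaker inhibition of growth and lower numbers for stronger inhibition of growth:
compound 1 `CC(C)c1n[nH]c2c(NCc3ccc(-c4ccccn4)cc3)nc(SC[C@H](O)CN)nc12` gives 63 nM
compound 2 `CC(C)c1n[nH]c2c(NCc3ccc(-c4ccccn4)cc3)nc(SCCn3ccnc3)nc12` gives 155 nM
compound 3 `C=CCSc1nc(NCc2ccc(-c3ccccn3)cc2)c2[nH]nc(C(C)C)c2n1` gives 1010 nM

Compound 3 stands with the highest number of the three, that is the weakest inhibition of growth: the step of a 6.5-fold higher number from compound 2 to compound 3 (0.81 log units; beyond the scatter) and the step of a 16-fold higher number from compound 1 to compound 3 (1.20 log units; beyond the scatter) both lie beyond the scatter. The next compound, compound 4 `CC(C)c1n[nH]c2c(NCc3ccc(-c4ccccn4)cc3)nc(SCCCO)nc12`, differs from compound 3 only in the chain on the sulfur: 2-hydroxyethyl in place of vinyl on a saturated chain carbon bound to a sulfur. Going by the values given here, two measured steps bear on this change. The step of a 16-fold higher number from compound 1 to compound 3 (1.20 log units; beyond the scatter) shows that going from a chain carrying a hydroxyl and an amine to vinyl brings a large loss; the step of a 6.5-fold higher number from compound 2 to compound 3 (0.81 log units; beyond the scatter) shows a smaller loss when an imidazole-bearing chain gives way to vinyl. Compound 4 brings back a hydroxyl but not the amine of compound 1, so only part of the gain seen in the step of a 16-fold higher number from compound 1 to compound 3 (1.20 log units; beyond the scatter) is expected to return; in this assay a modest drop in number, a 4.0-fold lower number from compound 3 to compound 4 (0.61 log units; beyond the scatter), is expected. For compound 4 the estimate is 250 nM, in a range from 80 nM to 800 nM.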

Compound 4, concentration for 50% growth inhibition: 109 nM
For compound 4 the middle estimate is 2.3-fold (0.36 log units) above the measured one; the measured number falls inside the stated range.
By their numbers in this assay, from the lowest: compounds 1, 4 and 2 (each within the scatter of the next, the first and the last beyond it); then compound 3.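

Replacing the allyl chain of compound 3 with the 3-hydroxypropyl chain of compound 4 brings a clear gain in this assay, with a 9.3-fold lower number from compound 3 to compound 4 (0.97 log units; beyond the scatter), so a simple chain ending in a hydroxyl is enough to leave the weak end of this short series. The amine and the imidazole are not required to reach this level: a 1.7-fold higher number from compound 1 to compound 4 (0.24 log units; within the scatter), and a 1.4-fold lower number from compound 2 to compound 4 (0.15 log units; within the scatter), so neither step can be told from repeat-measurement noise, even though compound 1 and compound 2 do stand apart from each other. Nothing measured here explains these differences.

On these data alone, this change both adds a hydroxyl and removes the double bond, so the share of each remains open. A plain propyl chain would separate the two, and a methoxy or carboxylic acid at the chain end would test what the hydroxyl can be exchanged for.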